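A few compounds are considered here, and "the series" means these few. Any claim that something is new, unique, unknown or untested is made for them only; others in the source may bear on it.

Compound 3, `[O-][n+]1nc(NCOCc2ccc(Cl)cc2)[n+]([O-])c2ccccc21`, gives the lowest of the three numbers measured in a functional assay on SMMC-7721 cells (Homo sapiens) for cytotoxicity, read by MTT assay, with a stated time of 72 h; a higher number here means a weaker inhibitor, a lower number a stronger inhibitor. In that assay compound 3 gives 810 nM, while compound 1, `COCNc1n[n+]([O-])c2ccccc2[n+]1[O-]`, gives 2480 nM and compound 2, `CCCCCOCNc1n[n+]([O-])c2ccccc2[n+]1[O-]`, gives 3050 nM. The steps toward compound 3 are a 3.1-fold lower number from compound 1 to compound 3 (0.49 log units; beyond the scatter) and a 3.8-fold lower number from compound 2 to compound 3 (0.58 log units; beyond the scatter); between the two chain compounds the step is a 1.2-fold higher number from compound 1 to compound 2 (0.09 log units; within the scatter).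

Compound 4, `CC(C)CCOCNc1n[n+]([O-])c2ccccc2[n+]1[O-]`, differs from compound 3 in one place: isobutyl in place of 4-chlorophenyl on a saturated chain carbon bound to an oxygen on a saturated carbon. Within the data shown here, the step that bears most directly on this is the one from compound 2 to compound 3, where the number fell once a 4-chlorophenyl replaced butyl; compound 4 reverses that kind of change, putting back a saturated chain that resembles the butyl of compound 2, and the step from compound 1 to compound 2 shows that such chains gave numbers within the scatter of each other. Compound 4 is therefore expected to show a modest rise, a 3.3-fold higher number from compound 3 to compound 4 (0.52 log units; beyond the scatter). Compound 4 is estimated at 2700 nM, with a range from 1300 nM to 5500 nM.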

Compound 4, half-maximal inhibitory concentration: 2860 nM
Beside the measured number, compound 4's estimate is 1.1-fold (0.03 log units) below it; the measured number falls inside the stated range.
By their numbers in this assay, from the lowest: compound 3; then compounds 1, 4 and 2 (each within the scatter of the next).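

Swapping the 4-chlorophenyl for isobutyl, on a saturated chain carbon bound to an oxygen on a saturated carbon, takes away the advantage of compound 3 in this assay (a 3.5-fold higher number from compound 3 to compound 4 (0.55 log units; beyond the scatter)). Branching the chain makes no difference that can be told apart from the scatter (a 1.1-fold lower number from compound 2 to compound 4 (0.03 log units; within the scatter)), and neither does isobutyl set against plain hydrogen (a 1.2-fold higher number from compound 1 to compound 4 (0.06 log units; within the scatter)), so among these four compounds the three without the 4-chlorophenyl sit together and compound 3 alone stands apart. Nothing measured here explains why this group differs from the saturated chains.

Among these compounds, compound 3 is the only one here with a ring at this position, so the ring and its chlorine cannot be separated; an unsubstituted phenyl would pull them apart. The compounds shown also leave open how an amine or a carboxylic acid at this position would read in this assay.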